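This account rests on a few compounds, and the source may have more. Where it says the series, first, only, none or still open, it means among the compounds named here.

In a functional assay on MDA-MB-468 cells (Homo sapiens) for inhibition, read by CCK-8 assay and cell counting, with a stated time of 2 days (a lower number here means a stronger inhibitor, a higher number a weaker inhibitor), compound 1 (`O=C(/C=C/c1ccco1)c1cccc(OCC2CO2)c1`) gives 37300 nM, compound 2 (`O=C(/C=C/c1ccco1)c1ccc(OCC2CO2)cc1`) gives 48900 nM and compound 3 (`O=C(/C=C/c1cccs1)c1ccc(OCC2CO2)cc1`) gives 17200 nM, the lowest of the three numbers. Compound 4 (`O=C(/C=C/c1ccoc1)c1ccc(OCC2CO2)cc1`) differs from compound 3 as follows: furan-3-yl in place of thiophen-2-yl on a double-bonded chain carbon bound to a double-bonded chain carbon. This places furan-3-yl in place of thiophen-2-yl on a double-bonded chain carbon. Within the data shown here, the one measured step bearing on this is a 2.8-fold lower number from compound 2 to compound 3 (0.45 log units; beyond the scatter), a modest change with furan-2-yl leaving and thiophen-2-yl entering at that place. Read in reverse, it points to a higher number in this assay on leaving thiophen-2-yl, though furan-3-yl itself is untested. The expected change is a modest rise, a 2.1-fold higher number from compound 3 to compound 4 (0.32 log units; beyond the scatter). Compound 4 is estimated at 36000 nM, with an expected range of 17000 nM to 75000 nM.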

Compound 4, half-maximal inhibitory concentration: 16500 nM
Compound 4: the middle estimate sits 2.2-fold (0.34 log units) above what was measured, and the stated range ends above it.
By their numbers in this assay, from the lowest: compounds 4 and 3 (each within the scatter of the next); then compounds 1 and 2 (each within the scatter of the next).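

In this assay, a 1.0-fold lower number from compound 3 to compound 4 (0.02 log units; within the scatter) leaves thiophen-2-yl and furan-3-yl unseparated at this place on the double-bonded chain carbon, so the lower number of compound 3 does not depend on a sulfur-bearing ring. Between the two furans, a 3.0-fold lower number from compound 2 to compound 4 (0.47 log units; beyond the scatter) comes from the change of furan-2-yl to furan-3-yl alone. No supporting measurement accounts for either step. From the compounds shown here alone, whether furan-3-yl gives the same step on the core of compound 1 remains open. So does how a phenyl ring or a pyridine ring would read at this place.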